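Replacing pyrrolidin-1-yl with 4-methylpiperidin-1-yl in an antiproliferative series

The source may hold more compounds than are shown below. What is called first, only, known or untested is meant among the compounds shown, and "the series" means these compounds.

In a functional assay on SH-SY5Y cells (Homo sapiens) for antiproliferative activity, read by MTT assay, with a stated time of 72 h (on this read-out lower numbers stand for stronger inhibition and higher numbers for weaker inhibition), compound 1 (`CCN(CC)CCCOc1cc2ncnc(Nc3ccc(C#N)cc3)c2cc1OC`) reaches only a limit (> 100000 nM). Compound 2 (`COc1cc2c(Nc3ccc(C#N)cc3)ncnc2cc1OCCCN(C)Cc1ccccc1`) also reaches only a limit (> 100000 nM). Going by the values given here, compound 3 (`COc1cc2c(Nc3ccc(C#N)cc3)ncnc2cc1OCCCN1CCCC1`) gives 8080 nM, the only true number so far and the strongest result of the three. Compound 4 (`COc1cc2c(Nc3ccc(C#N)cc3)ncnc2cc1OCCCN1CCC(C)CC1`) changes the amine on a saturated chain carbon, three bonds along the chain from an oxygen on an aromatic ring (4-methylpiperidin-1-yl in place of pyrrolidin-1-yl on a saturated chain carbon, three bonds along the chain from an oxygen on an aromatic ring). Two measured steps at this place bear on it: an at least 12-fold lower number from compound 1 to compound 3 (1.09 log units; beyond the scatter) and an at least 12-fold lower number from compound 2 to compound 3 (1.09 log units; beyond the scatter). Both are large and favour pyrrolidin-1-yl, though neither tests a six-membered ring. A weaker result is therefore expected, with an estimated 2.5-fold higher number from compound 3 to compound 4 (0.39 log units; beyond the scatter). For compound 4, the expected value is 20000 nM (range 5000 nM to 100000 nM).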

Compound 4, half-maximal inhibitory concentration: 7900 nM
Beside the measured number, compound 4's estimate is 2.5-fold (0.40 log units) above it; the measured number falls inside the stated range.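

In this assay, the swap gives a 1.0-fold lower number from compound 3 to compound 4 (0.01 log units; within the scatter), so 4-methylpiperidin-1-yl serves as well as pyrrolidin-1-yl here and the five-membered ring is not required. Compound 4 also shows an at least 12-fold lower number from compound 2 to compound 4 (1.10 log units; beyond the scatter) and an at least 12-fold lower number from compound 1 to compound 4 (1.10 log units; beyond the scatter), so both amines with the nitrogen in a ring stand clear of the two with the nitrogen outside one. Those two steps rest on limits, not numbers: the limit of > 100000 nM in this assay, at which 2 of the 4 values shown sit.

As far as these compounds go, whether piperidine without the methyl, morpholine or piperazine would hold this level stays open. So does the effect of a shorter or longer chain.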